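A few compounds are considered here, and "the series" means these few. Any claim that something is new, unique, unknown or untested is made for them only; others in the source may bear on it.

Measured in a functional assay on SF-295 cells (Homo sapiens) for antiproliferative activity, read by sulforhodamine B assay, with a stated time of 72 h; on this read-out lower numbers stand for stronger inhibition and higher numbers for weaker inhibition:
Compound 1 `O=C1CS/C(=N/Nc2nncc3ccccc23)N1c1ccccc1`: 4.6 nM
Compound 2 `S=C(NNc1nncc2ccccc12)Nc1ccccc1`: 9.5 nM

Of these two, compound 2 stands higher, at 9.5 nM, and its gap to compound 1 lies beyond the scatter. Compound 3 `COc1ccc(NC(=S)NNc2nncc3ccccc23)cc1` carries methoxy in place of hydrogen on an aromatic carbon of compound 2, para to a large group (methoxy in place of hydrogen on an aromatic carbon). Among the compounds with values here, no measured pair shows the effect of such a change. In this assay no shift beyond the scatter is therefore expected, and the estimate is a 1.3-fold higher number from compound 2 to compound 3 (0.10 log units; within the scatter). Compound 3 is expected at 12 nM, within an estimated range from 4 nM to 35 nM.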

Compound 3, half-maximal inhibitory concentration: 7.2 nM
Beside the measured number, compound 3's estimate is 1.7-fold (0.22 log units) above it; the range from low to high includes it.
By their numbers in this assay, from the lowest: compounds 1, 3 and 2 (each within the scatter of the next, the first and the last beyond it).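

In this assay, the step of a 1.3-fold lower number from compound 2 to compound 3 (0.12 log units; within the scatter) comes from methoxy in place of hydrogen on an aromatic carbon, para to a large group. Within the data shown here, it gives the first measured reading of this change and shows that this position accepts methoxy without a shift beyond the scatter. Nothing at hand explains this outcome.

On these data alone, whether an amine or a carboxylic acid at this position would also leave the number within the scatter stays open. So does whether methoxy would behave the same way on the phenyl ring of compound 1.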